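The source may report more compounds than this note shows. Statements on the series, on what has been measured and on what is new or still open speak of the compounds shown alone.

In a functional assay on HepG2 cells (Homo sapiens) for antiproliferative activity, read by sulforhodamine B assay, with a stated time of 72 h (on this read-out higher numbers stand for weaker inhibition and lower numbers for stronger inhibition), the measured compounds give only limits of the assay:

- Compound 1 `C[C@@H](NC(=O)OC(C)(C)C)C(=O)Nc1ccc2ncnc(Nc3cccc(C(F)(F)F)c3)c2c1`: limit of > 50000 nM
- Compound 2 `CC(C)C[C@@H](NC(=O)OC(C)(C)C)C(=O)Nc1ccc2ncnc(Nc3cccc(C(F)(F)F)c3)c2c1`: limit of > 50000 nM
- Compound 3 `CC[C@H](C)[C@@H](NC(=O)OC(C)(C)C)C(=O)Nc1ccc2ncnc(Nc3cccc(C(F)(F)F)c3)c2c1`: limit of > 50000 nM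

The series therefore offers no numerical value, only (the limit of > 50000 nM in this assay, at which 3 of the 3 values shown sit). Compound 4 `CC[C@H](C)[C@@H](NC(=O)OC(C)(C)C)C(=O)Nc1ccc2ncnc(Nc3cccc(Br)c3)c2c1` keeps the chain of compound 3 and carries bromo in place of trifluoromethyl on an aromatic carbon.

The measured steps all change the saturated chain, not this aromatic carbon. They are a step that the two limits leave unreadable from compound 1 to compound 2, a step that the two limits leave unreadable from compound 1 to compound 3 and a step that the two limits leave unreadable from compound 2 to compound 3. None of them gives a size or a direction for the change at hand.

Compound 3 provides the only starting point, and it is a limit: > 50000 nM. No step beyond the scatter can be forecast in this assay, and a further limit reading is the likeliest outcome. The expected change is a number no higher from compound 3 to compound 4 (the limit leaves the size open). For compound 4 the estimated value is 50000 nM, within an expected range of 15000 nM to 100000 nM.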

Compound 4, half-maximal inhibitory concentration: 34000 nM
Estimate against measurement, compound 4: 1.5-fold (0.17 log units) above; the measured number falls inside the stated range.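

In this assay, compound 4 is the only compound shown to give a number rather than a limit, and it carries bromo on the aromatic carbon where compound 3 carries trifluoromethyl. Compound 3 stands at > 50000 nM, which is a limit of the assay. Among the compounds shown here, the exchange at this position is therefore the first readable step, an at least 1.4-fold lower number from compound 3 to compound 4 (0.16 log units; that floor lies within the scatter), so it shows a lower number only by an amount that does not clear the scatter, and its full size remains open.

From the compounds shown here alone, whether other groups on this aromatic carbon, such as chloro, methoxy or an amine, would give a number remains open, as does the effect of bromo on the shorter chains of compound 1 and compound 2. The steps among compound 1, compound 2 and compound 3 cannot be read, and the chain's contribution stays unknown: the limit of > 50000 nM in this assay, at which 3 of the 4 values shown sit.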